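Notes on a trifluoromethyl step from compound 3

The source may hold more compounds than are shown below. What is called first, only, known or untested is meant among the compounds shown, and "the series" means these compounds.

Measured so far in a functional assay (mitochondria) for inhibition, with Rattus norvegicus as the target; on this read-out higher numbers stand for weaker inhibition and lower numbers for stronger inhibition:
- compound 1 `Cc1nc2cc(OC[C@H](O)CN3C(C)CN(CC(=O)Nc4c(C)cccc4C)CC3C)ccc2s1` gives 70 nM
- compound 2 `CCCc1nc2cc(OCC(O)CN3CCN(CC(=O)Nc4c(C)cccc4C)CC3)ccc2s1` gives 20000 nM
- compound 3 `Cc1cccc(C)c1NC(=O)CN1CCN(CC(O)COc2ccc3oc(-c4ccccc4)nc3c2)CC1` gives 23000 nM

Compound 3 at 23000 nM shares the high end of the range with compound 2 at 20000 nM and lies within the scatter of it. Compound 1 at 70 nM lies far lower, well beyond the scatter.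

The next compound to be read is compound 4 `Cc1cccc(C)c1NC(=O)CN1CCN(CC(O)COc2ccc3oc(-c4ccc(C(F)(F)F)cc4)nc3c2)CC1`. It has trifluoromethyl in place of hydrogen on an aromatic carbon, para to a large group trifluoromethyl in place of hydrogen on an aromatic carbon so that phenyl becomes 4-(trifluoromethyl)phenyl. Among the measured compounds shown here, no measured pair differs in one place only, so the data offer no direct guide to this change. Compound 2 at 20000 nM and compound 3 at 23000 nM carry different groups on the shared core and still read alike, which gives a weak reason to expect little movement. The expected change is a 1.6-fold lower number from compound 3 to compound 4 (0.22 log units; within the scatter) and is a small lowering at most, with nothing expected beyond the scatter. The estimated value for compound 4 is 14000 nM with an expected range from 4000 nM to 40000 nM in this read-out.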

Compound 4, half-maximal inhibitory concentration: 8000 nM
For compound 4 the middle estimate is 1.8-fold (0.24 log units) above the measured one; low and high end bracket the measured number.
By their numbers in this assay, from the lowest: compound 1; then compound 4; then compounds 2 and 3 (each within the scatter of the next).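

In this assay, among the compounds shown here, the change from phenyl to 4-(trifluoromethyl)phenyl provides the first step that differs in one place only: a 2.9-fold lower number from compound 3 to compound 4 (0.46 log units; beyond the scatter). This shows that the number at this position, on an aromatic carbon para to a large group, responds to the replacement of hydrogen by trifluoromethyl, and that the response is modest but lies beyond the scatter. Nothing available bears on the reason for this lowering.

Going by these compounds, a single pair gives the direction for trifluoromethyl alone, so it remains open whether fluorine, methyl, a nitrile, an amine or a carboxylic acid on the same carbon would lower the number, leave it unchanged or raise it. Also open, on these data alone, is whether trifluoromethyl would give a step of similar size on another carbon of the same six-membered ring, or on a compound that differs elsewhere on the shared core.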